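The compounds below may be only part of what the source reports. "The series", "measured", "known", "first", "only" and "open" are said of these compounds alone.

Values in a functional assay on MCF7 cells (Homo sapiens) for antiproliferative activity; on this read-out lower numbers stand for stronger inhibition and higher numbers for weaker inhibition:
- compound 1 `Nc1ccc(-c2nc3ccccc3s2)cc1Br`: < 1 nM (a limit)
- compound 2 `CC(=O)Nc1ccc(-c2nc3ccccc3s2)cc1C`: > 10000 nM (a limit)
- compound 3 `CC(=O)Nc1ccc(-c2nc3ccccc3s2)cc1Cl`: > 10 nM (a limit)

Compound 3 has no exact value in this assay. Compound 3 is known only through its limit of > 10 nM, and the other two compounds are also known only through limits.

The next compound, compound 4 `CC(=O)Nc1ccc(-c2nc3ccccc3s2)cc1Br`, has one structural change: bromo in place of chloro on an aromatic carbon. It has bromo in place of chloro on an aromatic carbon, ortho to an acetamido group.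

For the measured compounds named here, the one measured step that bears on this change is a step that the two limits leave unreadable from compound 2 to compound 3, which puts chloro in place of methyl at the same kind of place. Both ends of that step are limits, so it gives no size to carry over. It also involves a different swap. Compound 1 carries bromo too, and its limit is < 1 nM.

With so little to go on, no clear direction can be expected, and the expected change is loosely estimated as a step that the limit leaves unreadable from compound 3 to compound 4. For compound 4 the estimated value is 30 nM, with an expected range from 1 nM to 1000 nM.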

Compound 4, half-maximal inhibitory concentration: > 10 nM
Compound 4 was reported as a limit; the forecaster's own chance of this, stated with the estimate: 50%; the middle value is on the limit's open side.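

In this assay compound 4 is known only through a limit of > 10 nM and so gives no exact value for bromo at this place, ortho to an acetamido group. For the compounds shown here, what it adds is a first readable step with the bromo held fixed: acetyl in place of hydrogen on the nitrogen gives an at least 10-fold higher number from compound 1 to compound 4 (1.00 log units; beyond the scatter) and this lies beyond the scatter, so on this pair the acetylated compound has the weaker inhibition. The steps to compound 4 from compound 2 and from compound 3 cannot be read, because their ends are limits: the limit of > 10 nM in this assay, at which 2 of the 4 values shown sit.

On these data alone, whether bromo and chloro differ at this place remains open, as does whether the acetyl step would look the same with chloro or methyl on the ring. As far as these compounds go, how a longer acyl chain on the nitrogen or a fluoro group on the ring would read out is also open.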